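From Fluoro to Bromo on the Benzyl Group

The source may hold more compounds than are shown below. What is called first, only, known or untested is meant among the compounds shown, and "the series" means these compounds.

In an ADME assay on GES1 cells (Homo sapiens) for inhibition, read by MTT assay, with a stated time of 72 h (on this read-out lower numbers stand for stronger inhibition and higher numbers for weaker inhibition), compound 1 `Cc1cc(Nc2cc(-c3ccccc3)[nH]n2)n2nc(SCc3ccc(F)cc3)nc2n1` gives 35500 nM. Compound 2 `Cc1cc(Nc2cc(-c3cccs3)[nH]n2)n2nc(SCc3ccc(Br)cc3)nc2n1`, which carries a 4-bromobenzyl group, gives 38700 nM, so these two numbers lie within the scatter of each other and neither ranks ahead. Compound 3 `Cc1cc(Nc2cc(-c3ccccc3)[nH]n2)n2nc(SCC3CCCCC3)nc2n1` gives > 50000 nM, which is a limit of the assay and not a number.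

Compound 4 `Cc1cc(Nc2cc(-c3ccccc3)[nH]n2)n2nc(SCc3ccc(Br)cc3)nc2n1` is compound 1 with one atom exchanged: bromo in place of fluoro on an aromatic carbon. This places bromo in place of fluoro on an aromatic carbon, turning 4-fluorobenzyl into 4-bromobenzyl. Among the compounds with values here, the one measured step on this group replaces the whole ring with cyclohexyl, and it is an at least 1.4-fold higher number from compound 1 to compound 3 (0.14 log units; that floor lies within the scatter). That step is a much larger change than a single atom exchange, and it still shows nothing beyond the scatter. Compound 2 at 38700 nM also points to a 4-bromobenzyl group being compatible with a similar number. The expected step is therefore no larger than the scatter: a 1.0-fold higher number from compound 1 to compound 4 (0.01 log units; within the scatter). For compound 4 the estimated value is 36000 nM, with an expected range from 20000 nM to 50000 nM.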

Compound 4, half-maximal inhibitory concentration: 39300 nM
Estimate against measurement, compound 4: 1.1-fold (0.04 log units) below, and the stated range covers the measured number.
By their numbers in this assay, from the lowest: compounds 1, 2 and 4 (each within the scatter of the next). At a limit, above all of these: compound 3.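

In this assay, bromo in place of fluoro gives a 1.1-fold higher number from compound 1 to compound 4 (0.04 log units; within the scatter), so this single-atom exchange on the benzyl ring does not separate the two compounds. Compounds 1 and 2 differed in two places and could not be compared directly, but compound 4 now isolates the other change: phenyl in place of thiophen-2-yl, with the 4-bromobenzyl group held constant, gives a 1.0-fold higher number from compound 2 to compound 4 (0.01 log units; within the scatter), so that exchange also stays within the scatter. The step back to the cyclohexyl group reads an at least 1.2-fold lower number from compound 3 to compound 4 (0.10 log units; that floor lies within the scatter), and it remains only a floor because the value of compound 3 is a limit: the limit of > 50000 nM in this assay, at which 1 of the 4 values shown sits.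

Going by these compounds, whether an amine or a carboxylic acid in place of the bromo would move the number beyond the scatter stays open. So does the effect of a longer chain in place of the benzyl group.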